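The source may report more compounds than this note shows. Statements on the series, on what has been measured and on what is new or still open speak of the compounds shown alone.

Compound 1, `CC(C)/N=C(\NC#N)Nc1cc(C(F)(F)F)cc(C(F)(F)F)c1`, carries a cyanoguanidine linking an isopropyl group to an aryl ring bearing two trifluoromethyl groups. In a functional assay (aorta) with Rattus norvegicus as the target (on this read-out higher numbers stand for weaker inhibition and lower numbers for stronger inhibition), compound 1 gives 61000 nM. Compound 2, `CCC(C)(C)/N=C(\NC#N)Nc1cc(C(F)(F)F)cc(C(F)(F)F)c1`, keeps that core and differs by ethyl in place of hydrogen on a saturated chain carbon bound to a double-bonded nitrogen and two saturated chain carbons. Measured in this assay, compound 2 gives 900 nM, which is a 68-fold lower number from compound 1 to compound 2 (1.83 log units; beyond the scatter).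

Compound 3, `CC(C)/N=C(\NC#N)Nc1cc(Cl)cc(Cl)c1`, replaces the trifluoromethyl groups with chlorines; the difference between its core and that of compound 1 is not broken down here. In this assay compound 3 gives 52000 nM, a number that lies within the scatter of the value of compound 1, so the two cores appear to behave alike on this read-out.

Compound 4, `CCC(C)(C)/N=C(\NC#N)Nc1cc(Cl)cc(Cl)c1`, is not yet measured in this assay. Relative to compound 3 it differs by ethyl in place of hydrogen on a saturated chain carbon bound to a double-bonded nitrogen and two saturated chain carbons, the same change that separates compound 1 from compound 2, at the same place. On the strength of a 68-fold lower number from compound 1 to compound 2 (1.83 log units; beyond the scatter), and since compound 3 gives 52000 nM close to compound 1, compound 4 is expected to show a 65-fold lower number from compound 3 to compound 4 (1.81 log units; beyond the scatter). Compound 4 is therefore estimated at 800 nM, with a likely range from 250 nM to 2500 nM.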

Compound 4, half-maximal inhibitory concentration: 300 nM
The estimate for compound 4 lay 2.7-fold (0.43 log units) above the measured number; low and high end bracket the measured number.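

Going from isopropyl to 1,1-dimethylpropyl on the dichloro core gives a 170-fold lower number from compound 3 to compound 4 (2.24 log units; beyond the scatter) in this assay, so the change that lowered the number on the core of compound 1 does the same on the core of compound 3. Set side by side, the two steps do not differ beyond what repeated measurements allow: the same change on two cores in this assay, a 68-fold lower number (1.83 log units; beyond the scatter) from compound 1 to compound 2 and a 170-fold lower number (2.24 log units; beyond the scatter) from compound 3 to compound 4, 2.6-fold (0.41 log units) apart, within the scatter of two such steps. This shows that the change carried over between these two cores on this read-out, but with one pair per core it does not show that the change would carry to any other core, and it does not explain why the number falls.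

The compounds shown leave open whether tert-butyl or a longer chain such as 1,1-dimethylbutyl would follow the same course in place of 1,1-dimethylpropyl. They also leave open whether the step would hold with methoxy or fluorine groups in place of the chlorines or the trifluoromethyl groups.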